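A few compounds are considered here, and "the series" means these few. Any claim that something is new, unique, unknown or untested is made for them only; others in the source may bear on it.

In an ADME assay on L1210/0 cells (Mus musculus) for cytotoxicity, with a stated time of 48 h (a lower number here means a stronger inhibitor, a higher number a weaker inhibitor), compound 1 `C=Cc1cn([C@H]2C[C@H](O)[C@@H](CO)O2)c(=O)[nH]c1=O` gives 14200 nM and compound 2 `O=C(CI)NCc1cn([C@H]2C[C@H](O)[C@@H](CO)O2)c(=O)[nH]c1=O` gives 107000 nM. Compound 3 `O=c1[nH]c(=O)n([C@H]2C[C@H](O)[C@@H](CO)O2)cc1/C=C/Cl` gives > 200000 nM, which is a limit of the assay and not a number. Compound 4 `CCCCC#Cc1cn([C@H]2C[C@H](O)[C@@H](CO)O2)c(=O)[nH]c1=O` differs from compound 3 in a single group: hex-1-yn-1-yl replaces 2-chloroethenyl on an aromatic carbon, (hex-1-yn-1-yl in place of 2-chloroethenyl on an aromatic carbon). All three measured steps change this same position. Replacing vinyl gave a 7.5-fold higher number from compound 1 to compound 2 (0.88 log units; beyond the scatter) and an at least 14-fold higher number from compound 1 to compound 3 (1.14 log units; beyond the scatter), both beyond the scatter, while an at least 1.8-fold higher number from compound 2 to compound 3 (0.27 log units; that floor lies within the scatter) has a floor within the scatter. None of these steps introduces hex-1-yn-1-yl, so they offer only a rough guide. Compound 1 alone sits at a clearly lower number, and both replacements of its vinyl moved the number up, so compound 4 is expected to stay weak in this assay, near compound 2 or the limit. The expected change is an at least 1.6-fold lower number from compound 3 to compound 4 (0.22 log units; that floor lies within the scatter), an estimate measured against a limit rather than a true number. For compound 4 the estimated value is 120000 nM, with an expected range from 40000 nM to 300000 nM.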

Compound 4, half-maximal inhibitory concentration: > 200000 nM
Compound 4: a limit, no number (the forecaster's own chance of this, stated with the estimate: 45%); at least 1.6-fold (0.22 log units) between middle value and limit.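

In this assay compound 4 gives > 200000 nM, which is a limit of the assay and not a number. Hex-1-yn-1-yl is now a third replacement for vinyl that leaves the compound clearly weaker, with an at least 14-fold higher number from compound 1 to compound 4 (1.14 log units; beyond the scatter), and this holds for all the replacements shown; against the other replacement, the iodoacetamide-bearing group, the data give only an at least 1.8-fold higher number from compound 2 to compound 4 (0.27 log units; that floor lies within the scatter), a floor that does not separate the two. The step between compound 3 and compound 4 cannot be read because both values are limits: the limit of > 200000 nM in this assay, at which 2 of the 4 values shown sit.

On these data alone, whether any group on this aromatic carbon can match or beat the vinyl of compound 1 remains open. An ethyl or ethynyl group would show whether the activity of compound 1 depends on vinyl itself.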